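The source may report more compounds than this note shows. Statements on the series, on what has been measured and on what is new or still open speak of the compounds shown alone.

Measured so far in a functional assay on BGC-823 cells (Homo sapiens) for antiproliferative activity, read by MTT assay, tested at 1 uM; a higher number here means a stronger effect of the compound at the concentration tested, a lower number a weaker effect:
- compound 1, `COc1cc(C2=NN(C(C)=O)C(c3ccc(Cl)c(Cl)c3)O2)cc(OC)c1OC`, gives -0.8%
- compound 2, `COc1cc(C(=O)N/N=C/c2ccc(Cl)c([N+](=O)[O-])c2)cc(OC)c1OC`, gives -5.8%
- compound 3, `COc1cc(C2=NN(C(C)=O)C(c3ccc(Cl)c([N+](=O)[O-])c3)O2)cc(OC)c1OC`, gives -2.3%

All three numbers sit close together, and none of the gaps between them is beyond the usual scatter, so no ordering among compound 1, compound 2 and compound 3 is claimed. For the measured compounds named here, the one change that is measured directly is the step from compound 3 to compound 1: chloro in place of nitro on an aromatic carbon. In this assay that step reads a number 1.5 percentage points higher from compound 3 to compound 1 (within the scatter).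

Compound 4, `COc1cc(C(=O)N/N=C/c2ccc(Cl)c(Cl)c2)cc(OC)c1OC`, is not yet measured. It arises from compound 2 by the same kind of change: chloro in place of nitro on an aromatic carbon. The place lines of the two changes agree word for word, so this is the same change made on a different core. How the core of compound 2 differs from the core of compound 3 is not broken down here.

Given that the only measured instance of this change, from compound 3 to compound 1, stayed within the scatter, the step from compound 2 to compound 4 is expected to be of the same small size, estimated as a number 1.8 percentage points higher from compound 2 to compound 4 (within the scatter). On that basis compound 4 is expected to give about -4% in this assay. The expected range for compound 4 runs from -15% to 8%, which rests on compound 2 at -5.8% and on the scatter of single-concentration measurements of this kind. A number near zero, with no clear effect at the tested concentration, is the working expectation for compound 4.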

Compound 4, a percentage reported as inhibition, at one concentration (the size of the read-out at that concentration, not a potency): 29.6%
For compound 4 the middle estimate is 33.6 percentage points below the measured one; measured number outside the range, above it.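

In this assay, chloro in place of nitro on an aromatic carbon gives a clear gain on the core of compound 2, with the step reading a number 35.4 percentage points higher from compound 2 to compound 4 (beyond the scatter). Set beside the only other instance of this change, the step does not keep its size from one core to the other: the same change on two cores in this assay, a number 1.5 percentage points higher (within the scatter) from compound 3 to compound 1 and a number 35.4 percentage points higher (beyond the scatter) from compound 2 to compound 4, 33.9 percentage points apart, beyond the scatter of two such steps These two pairs show that, within this series, the result of this change on one core cannot be taken as a guide to its result on the other, but they do not show which difference between the cores sets the two steps apart, or whether any other change would behave in the same way.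

The compounds shown carry only chloro or nitro at this place, so it remains open how an amine or a carboxylic acid there would read in this assay on either core. Also open, going by these compounds, is how compound 4 would behave across a range of concentrations, since a read-out at one concentration is not a potency, and whether the large step on the core of compound 2 would appear in a cell line other than the one tested.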